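The source may hold more compounds than are shown below. What is called first, only, known or untested is meant among the compounds shown, and "the series" means these compounds.

Of the compounds shown here, two built on the same core have been measured in a functional assay on U-937 cells (Homo sapiens) for cytotoxicity, read by WST assay, with a stated time of 72 h; on this read-out lower numbers stand for stronger inhibition and higher numbers for weaker inhibition. Compound 1 `COc1cc2c(Nc3nc4ccc(C(=O)Nc5c(C)cc(C)cc5C)cc4s3)ncnc2cc1OCCCN1CCCCC1C` gives 3600 nM in this assay. Compound 2 `CCN(CC)CCCOc1cc2ncnc(Nc3nc4ccc(C(=O)Nc5c(C)cc(C)cc5C)cc4s3)c2cc1OC` gives 4300 nM, the highest of the two numbers, although the step of a 1.2-fold higher number from compound 1 to compound 2 (0.08 log units; within the scatter) lies within the scatter, so the two compounds cannot be told apart on this evidence.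

Compound 3 `COc1cc2c(Nc3nc4ccc(C(=O)Nc5c(C)cc(C)cc5C)cc4s3)ncnc2cc1OCCCN1CCCCC1` has not yet been measured. It differs from compound 2 by piperidin-1-yl in place of diethylamino on a saturated chain carbon, three bonds along the chain from an oxygen on an aromatic ring. Within the data shown here, the only measured step that bears on this change is a 1.2-fold higher number from compound 1 to compound 2 (0.08 log units; within the scatter), which swapped a ring amine for an open-chain amine at the same place on the chain and produced no change beyond the scatter. Going back from the open-chain amine to a ring amine is therefore expected to change little, and the estimated step of a 1.1-fold lower number from compound 2 to compound 3 (0.05 log units; within the scatter) stays within the scatter. Compound 3 is expected to give about 3800 nM in this assay, with a range from 1500 nM to 9000 nM.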

Compound 3, half-maximal inhibitory concentration: 12200 nM
Estimate against measurement, compound 3: 3.2-fold (0.51 log units) below, and the stated range ends below it.
By their numbers in this assay, from the lowest: compounds 1 and 2 (each within the scatter of the next); then compound 3.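

In this assay, the step of a 2.8-fold higher number from compound 2 to compound 3 (0.45 log units; beyond the scatter) shows that the amine at the end of this chain can matter: piperidin-1-yl in place of diethylamino is not a neutral swap here, even though the earlier pair gave no sign of this. The step of a 3.4-fold higher number from compound 1 to compound 3 (0.53 log units; beyond the scatter) shows that a single methyl on a saturated ring carbon also counts, with hydrogen in its place giving the weakest of the three compounds. The data at hand offer no explanation for either step.

On these data alone, whether the methyl would count the same at another ring carbon remains open. So does whether a pyrrolidine or morpholine ring at the same place on the chain would fall nearer compound 2 or compound 3.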